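Side-chain isomers in the stomach series of esters

The compounds below may be only part of what the source reports. "The series", "measured", "known", "first", "only" and "open" are said of these compounds alone.

Values in a functional assay on the whole organism (stomach) with Canis familiaris (Canis lupus familiaris) as the target; on this read-out higher numbers stand for an effect only at larger amounts of compound and lower numbers for an effect already at smaller amounts:
- compound 1 `COC(=O)CC/C=C\CC[C@H]1C(=O)C[C@@H](O)[C@@H]1/C=C/CC(C)(O)CCC1CC1`: 0.00009 mg/kg
- compound 2 `COC(=O)CC/C=C\CC[C@H]1C(=O)C[C@@H](O)[C@@H]1/C=C/C[C@@](C)(O)C#CC1=CCCC1`: 0.0028 mg/kg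
- compound 3 `COC(=O)CC/C=C\CC[C@H]1C(=O)C[C@@H](O)[C@@H]1/C=C/C[C@@](C)(O)/C=C/C1CCCC1`: 0.0003 mg/kg

Compound 3 holds the middle of the three numbers. Compound 4 `COC(=O)CC/C=C\CC[C@H]1C(=O)C[C@@H](O)[C@@H]1/C=C/CC(C)(O)CCC1=CCCC1` is an isomer of it: 3-(cyclopent-1-en-1-yl)-1-hydroxy-1-methylpropyl in place of 3-cyclopentyl-1-hydroxy-1-methylprop-2-en-1-yl on a saturated chain carbon bound to a double-bonded chain carbon, with 3-(cyclopent-1-en-1-yl)-1-hydroxy-1-methylpropyl in place of 3-cyclopentyl-1-hydroxy-1-methylprop-2-en-1-yl. Compound 1 also carries a propyl group here, and the nearest guide is a 3.3-fold higher number from compound 1 to compound 3 (0.52 log units; beyond the scatter). Compound 2 shares the cyclopent-1-en-1-yl ring, but a 31-fold higher number from compound 1 to compound 2 (1.49 log units; beyond the scatter) and a 9.3-fold lower number from compound 2 to compound 3 (0.97 log units; beyond the scatter) also involve the ethynyl link, which compound 4 lacks. A small shift towards compound 1 is therefore expected, not beyond the scatter. The expected change is a 1.5-fold lower number from compound 3 to compound 4 (0.18 log units; within the scatter). For compound 4 the estimate is 0.0002 mg/kg, with an expected range of 0.00006 mg/kg to 0.0008 mg/kg.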

Compound 4, dose for half-maximal effect: 0.0001 mg/kg
For compound 4 the middle estimate is 2.0-fold (0.30 log units) above the measured one; the range from low to high includes it.
By their numbers in this assay, from the lowest: compounds 1 and 4 (each within the scatter of the next); then compound 3; then compound 2.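

Putting 3-(cyclopent-1-en-1-yl)-1-hydroxy-1-methylpropyl on the saturated chain carbon gives a 3.0-fold lower number from compound 3 to compound 4 (0.48 log units; beyond the scatter) and a 28-fold lower number from compound 2 to compound 4 (1.45 log units; beyond the scatter) and shows that these isomeric or closely related side chains are not interchangeable at this position. With a 1.1-fold higher number from compound 1 to compound 4 (0.05 log units; within the scatter) as the step, cyclopent-1-en-1-yl and cyclopropyl cannot be told apart on this chain. Nothing on hand explains these steps.

The compounds shown leave open whether a free carboxylic acid in place of the methyl ester follows the same steps. Also open, as far as these compounds go, is whether a longer chain between the hydroxy-bearing carbon and the ring is tolerated.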